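From 4-ethoxyphenyl to cyclopentyl on the shared core

The source may report more compounds than this note shows. Statements on the series, on what has been measured and on what is new or still open speak of the compounds shown alone.

Within the data shown here, in a functional assay on MCF7 cells (Homo sapiens) for cytotoxicity, read by WST assay, with a stated time of 72 h (on this read-out lower numbers stand for stronger inhibition and higher numbers for weaker inhibition), compound 1 `CCOc1ccc(C2(c3ccc(O)cc3)C(=O)Nc3c2ccc(F)c3F)cc1` gives 11 nM, the lowest of the three numbers measured so far. Compound 2 `CCCOc1ccc(C2(c3ccc(O)cc3)C(=O)Nc3c2ccc(F)c3F)cc1` gives 356 nM. Compound 3 `COc1ccc(C2(c3cccc(O)c3)C(=O)Nc3c2ccc(F)c3F)cc1` gives 196 nM, and compound 1 stands well clear of both.

Compound 4 `O=C1Nc2c(ccc(F)c2F)C1(c1ccc(O)cc1)C1CCCC1` keeps the core of compound 1 but carries cyclopentyl in place of 4-ethoxyphenyl on a saturated ring carbon. Among the measured compounds shown here, no measured step covers a swap of this kind. For the measured compounds named here, the one step that bears on it is a 32-fold higher number from compound 1 to compound 2 (1.51 log units; beyond the scatter), in which a methyl replaces a hydrogen on a saturated chain carbon of the same group. That large step, beyond the scatter, shows that this assay responds strongly to a small edit of this group in compound 1, so removing the whole group is expected to matter too. It is a single step, so the size remains uncertain. The expected change is an 18-fold higher number from compound 1 to compound 4 (1.26 log units; beyond the scatter), towards a higher number. Compound 4 is estimated at 200 nM, with an expected range from 30 nM to 1500 nM.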

Compound 4, half-maximal inhibitory concentration: 12 nM
Compound 4: middle estimate off by 17-fold (1.22 log units), on the high side, outside the stated range (below it).
By their numbers in this assay, from the lowest: compounds 1 and 4 (each within the scatter of the next); then compounds 3 and 2 (each within the scatter of the next).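

In this assay, cyclopentyl in place of 4-ethoxyphenyl on a saturated ring carbon gives a 1.1-fold higher number from compound 1 to compound 4 (0.04 log units; within the scatter), so at this position the shared core does not depend on the aromatic ring or the oxygen of the group that leaves, and a five-membered non-aromatic ring of carbon only, with fewer heavy atoms, serves as well. The earlier step, a 32-fold higher number from compound 1 to compound 2 (1.51 log units; beyond the scatter), showed that adding one methyl to the ethoxy chain is not tolerated in this assay, yet the new step shows that replacing the whole group need not carry any such cost. No measurement available here accounts for the contrast between these two steps.

From the compounds shown here alone, it remains open whether cyclohexyl, cyclobutyl or an open chain such as isopropyl would read like cyclopentyl at this carbon. Whether an amine or a hydroxyl on the cyclopentyl ring would be tolerated is also unresolved.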